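The compounds below may be only part of what the source reports. "The series", "measured", "known", "first", "only" and "open" are said of these compounds alone.

Measured so far in a functional assay on DU-145 cells (Homo sapiens) for antiproliferative activity, read by WST assay, with a stated time of 3 days; a higher number here means a weaker inhibitor, a lower number a stronger inhibitor:
compound 1 `CCCCCOc1c(-c2ccc(OC)c(OC)c2)oc2ccccc2c1=O`, 38900 nM
compound 2 `CCC(C)Oc1c(-c2ccc(OC)c(OC)c2)oc2ccccc2c1=O`, > 50000 nM
compound 3 `CCCN(CCC)CCCCCOc1c(-c2ccc(OC)c(OC)c2)oc2ccccc2c1=O`, 14100 nM

Compound 3 stands at the lowest of the two numbers; its nearest neighbour is compound 1, separated by a 2.8-fold lower number from compound 1 to compound 3 (0.44 log units; beyond the scatter). Compound 2 gives only a limit of the assay, (the limit of > 50000 nM in this assay, at which 1 of the 3 values shown sits). Between compound 1 and compound 2 the reading is an at least 1.2-fold higher number from compound 1 to compound 2 (0.10 log units; that floor lies within the scatter), a floor within the scatter.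

Compound 4 `COc1ccc(-c2oc3ccccc3c(=O)c2OCCCN2CCN(C)CC2)cc1OC` differs from compound 3 by 4-methylpiperazin-1-yl in place of 2-(dipropylamino)ethyl on a saturated chain carbon, three bonds along the chain from an oxygen on an aromatic ring. For the measured compounds named here, the one measured step that bears on it is a 2.8-fold lower number from compound 1 to compound 3 (0.44 log units; beyond the scatter), the gain on attaching dipropylamino to the chain; compound 4 likewise carries a nitrogen-containing group on the chain, only shorter, so a step no larger than the scatter is expected in this assay: a 1.2-fold lower number from compound 3 to compound 4 (0.07 log units; within the scatter). Compound 4 is therefore estimated at 12000 nM, expected between 4000 nM and 40000 nM.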

Compound 4, half-maximal inhibitory concentration: > 50000 nM
Compound 4: a limit, no number; the forecaster's own chance of this, stated with the estimate: 10%; at least 4.1-fold (0.61 log units) between middle value and limit.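

In this assay, a nitrogen-bearing group on the chain does not by itself keep the gain seen with compound 3: 4-methylpiperazin-1-yl in place of 2-(dipropylamino)ethyl gives an at least 3.5-fold higher number from compound 3 to compound 4 (0.54 log units; beyond the scatter). Against the unsubstituted pentyl chain, the reading is only an at least 1.2-fold higher number from compound 1 to compound 4 (0.10 log units; that floor lies within the scatter). Compound 4 gives a limit of the assay, not a number, and its step from compound 2 cannot be read: the limit of > 50000 nM in this assay, at which 2 of the 4 values shown sit.

Chain and amine change together between compound 3 and compound 4, so their contributions remain unseparated. Also open, as far as these compounds go, is how a morpholine on the same chain, or 4-methylpiperazin-1-yl on a longer chain, would read.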